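The source may hold more compounds than are shown below. What is called first, only, known or untested is meant among the compounds shown, and "the series" means these compounds.

Within the data shown here, in an assay on isolated protein for inhibition of mitogen-activated protein kinase kinase kinase 11 (Homo sapiens), tested at 1 uM (on this read-out lower numbers stand for less inhibition and higher numbers for more inhibition at the one concentration tested (going by the name of the read-out)), compound 1 `N#CCOc1ccc2c(c1)CCc1c-2c2c(c3c4ccccc4n(CCO)c13)CNC2=O` gives 8%, and compound 2 `O=C1NCc2c1c1c(c3c2c2ccccc2n3CCO)CCc2cc(OCc3ccccn3)ccc2-1` gives 30%, the higher of the two numbers, its only neighbour being compound 1 with a step of a number 22 percentage points higher from compound 1 to compound 2 (beyond the scatter). Compound 3 `O=C1NCc2c1c1c(c3c2c2ccccc2n3CCO)CCc2cc(OCCOCc3ccccc3)ccc2-1` differs from compound 2 in one place: (benzyloxy)methyl in place of pyridin-2-yl on a saturated chain carbon bound to an oxygen on an aromatic ring. That earlier step is the only one at this carbon, and it exchanged a different pair of groups, so it carries little over to this change; a step of no size beyond the scatter is expected, a number 5 percentage points lower from compound 2 to compound 3 (within the scatter). Compound 3 is therefore estimated at 25%, within a range from 5% to 50%.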

Compound 3, a percentage reported as inhibition, at one concentration (the size of the read-out at that concentration, not a potency): 0%
Beside the measured number, compound 3's estimate is 25 percentage points above it, and the stated range ends above it.
By their numbers in this assay, from the lowest: compounds 3 and 1 (each within the scatter of the next); then compound 2.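

With (benzyloxy)methyl in place of pyridin-2-yl on this carbon, the read-out shows a number 30 percentage points lower from compound 2 to compound 3 (beyond the scatter), so a six-membered aromatic ring on this chain does not by itself keep the number of compound 2. The group with the carbon-only ring gives no separation from the cyano group, with a number 8 percentage points lower from compound 1 to compound 3 (within the scatter). Nothing at hand explains this difference.

The ring nitrogen and the length of the chain change together here, and the compounds shown do not separate them. A phenyl group on this same carbon would bear on that question.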